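Piperidine carboxamide series: second chloro on the benzyl ring

The compounds below may be only part of what the source reports. "The series", "measured", "known", "first", "only" and "open" are said of these compounds alone.

Measured compounds:
compound 1, `CC(C)NC(=O)C1CCN(Cc2ccc(Cl)cc2)CC1`, 637 nM
compound 2, `CC(C)NC(=O)C1CCN(Cc2ccccc2)CC1`, 1070 nM

In an assay for displacement of a labelled ligand from Sigma non-opioid intracellular receptor 1 (Cavia porcellus) (on this read-out higher numbers stand for weaker inhibition and lower numbers for stronger inhibition), compound 1 gives 637 nM. Among the compounds with values here, the only comparison available is with compound 2, which in this assay gives 1070 nM; the two numbers are not separated beyond the scatter, so compound 1 cannot be called more or less potent than compound 2 on what is known.

Compound 3, `CC(C)NC(=O)C1CCN(Cc2ccc(Cl)cc2Cl)CC1`, is not yet measured. It differs from compound 1 by chloro in place of hydrogen on an aromatic carbon. Within the data shown here, the one step that bears on the influence of a chloro group on this ring is a 1.7-fold higher number from compound 1 to compound 2 (0.23 log units; within the scatter), which stayed within the scatter. Among the measured compounds shown here, no step has been measured for a chloro group at the place that compound 3 carries it. The expectation for compound 3 in this assay is therefore a small step, if any, with no direction established beyond the scatter; the estimate is 450 nM, between 150 nM and 1400 nM, corresponding to an expected step of a 1.4-fold lower number from compound 1 to compound 3 (0.15 log units; within the scatter).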

Compound 3, inhibition constant: > 2000 nM
Compound 3: only a limit was reported; the forecaster's own chance of this, stated with the estimate: 5%; middle value at least 4.4-fold (0.64 log units) away from the limit.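

In this assay, within the data shown here, a chloro group entering on the aromatic carbon ortho to a large group and meta to a chloro group gives the first step that lies beyond the scatter: an at least 3.1-fold higher number from compound 1 to compound 3 (0.49 log units; beyond the scatter). Among these compounds, the only earlier step, a 1.7-fold higher number from compound 1 to compound 2 (0.23 log units; within the scatter), stayed within the scatter, so it gave no sign that this place on the ring would respond differently to a chloro group. The value for compound 3 is a limit and not a number, so the step gives only a minimum size: the limit of > 2000 nM in this assay, at which 1 of the 3 values shown sits.

On these data alone, the full size of the step remains unknown. As far as these compounds go, it is also open whether a fluoro, methyl or methoxy group at this place would raise the number as well, and whether a chloro group here would do so without the other chloro group on the ring.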